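The compounds below may be only part of what the source reports. "The series", "measured", "known", "first", "only" and "open" are said of these compounds alone.

Of the compounds shown here, three that share one core have been measured in an assay on HeLa cells for inhibition of sphingosine-1-phosphate transporter SPNS2 (Mus musculus), read by LC-MS, tested at 2 uM; on this read-out lower numbers stand for less inhibition and higher numbers for more inhibition at the one concentration tested (going by the name of the read-out). Compound 1 `CCCCCCCCCCc1ccc(-c2noc(C3CNC3)n2)cc1` carries an azetidin-3-yl group on an aromatic carbon of that core, and in this assay compound 1 gives 65%. Compound 2 `CCCCCCCCCCc1ccc(-c2noc([C@@H]3CCC[C@@H](N)C3)n2)cc1` carries a 3-aminocyclohexyl group in its place, and compound 2 gives 13%, a result that is a number 52 percentage points lower from compound 1 to compound 2 (beyond the scatter). Compound 3 `CCCCCCCCCCc1ccc(-c2noc(CC(O)CN)n2)cc1` carries a 3-amino-2-hydroxypropyl group, and compound 3 gives 59%, the second highest of the three numbers; this is a number 6 percentage points lower from compound 1 to compound 3 (within the scatter) and a number 46 percentage points higher from compound 2 to compound 3 (beyond the scatter).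

The next compound, compound 4 `CCCCCCCCCCc1ccc(-c2noc([C@H](CCCCN)NC(C)=O)n2)cc1`, differs from compound 3 in one place: 1-acetamido-5-aminopentyl in place of 3-amino-2-hydroxypropyl on an aromatic carbon. Among the measured compounds shown here, two measured steps bear on this change. The step of a number 6 percentage points lower from compound 1 to compound 3 (within the scatter) shows that exchanging a small ring group for a group with no ring stayed within the scatter, while the step of a number 46 percentage points higher from compound 2 to compound 3 (beyond the scatter) shows that a ring group bearing an amine gave a far lower number. The entering group has no ring but is larger than the leaving one, so a moderate fall is expected, a number 19 percentage points lower from compound 3 to compound 4 (beyond the scatter), with wide uncertainty. Compound 4 is therefore expected to give 40%, between 10% and 70%.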

Compound 4, a percentage reported as inhibition, at one concentration (the size of the read-out at that concentration, not a potency): 40%
For compound 4 middle estimate and measured number coincide at the digits printed, and the stated range covers the measured number.
By their numbers in this assay, from the lowest: compound 2; then compound 4; then compounds 3 and 1 (each within the scatter of the next).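

In this assay, this position of the shared core still gives a clear reading with a larger open chain, but the two groups with no ring are no longer equivalent: 1-acetamido-5-aminopentyl falls short of 3-amino-2-hydroxypropyl (a number 19 percentage points lower from compound 3 to compound 4 (beyond the scatter)) and of azetidin-3-yl (a number 25 percentage points lower from compound 1 to compound 4 (beyond the scatter)). The same chain still stands well clear of 3-aminocyclohexyl (a number 27 percentage points higher from compound 2 to compound 4 (beyond the scatter)), so having no ring does not by itself fix the number, and this ringless chain lands in the middle of the series. Nothing available explains the size of these steps.

As far as these compounds go, the acetamido branch and the longer amine-bearing chain enter together, so their shares in the fall remain open. The same pentyl chain with a free amine in place of the acetamido group, or a carboxylic acid in place of the terminal amine, would help separate them.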